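Replacing diethylamino with butyl on a potent compound

The compounds below may be only part of what the source reports. "The series", "measured", "known", "first", "only" and "open" are said of these compounds alone.

Compound 1 `CCN(CC)c1ccc(N2C(=O)NC3(CSC4=C3C(=O)c3ncccc3C4=O)C2=O)cc1` gives 8 nM in the measurements so far
Compound 2 `O=C1NNC(=O)C2(CSC3=C2C(=O)c2ncccc2C3=O)N1` gives 550 nM; 500 nM; 550 nM (3 entries) in the measurements so far

For the measured compounds named here, in a functional assay on MT4 cells (Homo sapiens) for antiproliferative activity, read by MTT assay, with a stated time of 96 h (a higher number here means a weaker inhibitor, a lower number a stronger inhibitor), compound 1 gives 8 nM as its only number, with one further entry that carries no single number. That is a lower number than the several entries of compound 2 in this assay, 550 nM; 500 nM; 550 nM (3 entries) show.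

Compound 3 `CCCCc1ccc(N2C(=O)NC3(CSC4=C3C(=O)c3ncccc3C4=O)C2=O)cc1` has not yet been measured. It differs from compound 1 in one place (butyl in place of diethylamino on an aromatic carbon): butyl in place of diethylamino on an aromatic carbon, para to a large group. Going by the values given here, no measured step shows what this exchange does, so the expectation rests on compound 1 at 8 nM alone. A small weakening is expected, slightly beyond the scatter. The expected step runs a 2.5-fold higher number from compound 1 to compound 3 (0.40 log units; beyond the scatter) and remains modest. For compound 3 the estimated value is 20 nM with an expected range from 6 nM to 70 nM as its limits.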

Compound 3, half-maximal inhibitory concentration: 200 nM
The estimate for compound 3 lay 10-fold (1.00 log units) below the measured number; the whole stated range lies below it.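

In this assay, the exchange of diethylamino for butyl on an aromatic carbon, para to a large group, gives a 25-fold higher number from compound 1 to compound 3 (1.40 log units; beyond the scatter) and so marks this position as one where the choice of group matters greatly. Until this pair, compound 1 stood alone and gave no sign of how much of its potency depended on the diethylamino group. The exchange removes the nitrogen and the hydrogen-bond acceptor counted in diethylamino, but this single pair cannot show whether either loss accounts for the step, and no measurement shown bears on its cause.

The compounds shown leave open how a smaller amine such as dimethylamino would read at this position. The same holds for an ether such as butoxy and for a longer carbon chain.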